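The compounds below may be only part of what the source reports. "The series", "measured", "known", "first", "only" and "open" are said of these compounds alone.

Compound 1 `CC(=O)C(C)Nc1ccc(C(=O)Nc2ccn([C@H]3CC[C@H](O)[C@@H](C)O3)c(=O)n2)cc1`: in a functional assay on HCT-116 cells (Homo sapiens) for cytotoxicity, read by sulforhodamine B assay, with a stated time of 24 h (on this read-out higher numbers stand for weaker inhibition and lower numbers for stronger inhibition), compound 1 gives only a limit, > 20000 nM.
Compound 2 `CC(C)CCC(=O)Nc1ccn([C@H]2CC[C@H](O[C@H]3O[C@H](C)[C@@H](N(C)C)[C@H](O)[C@H]3O)[C@@H](C)O2)c(=O)n1`: in this assay compound 2 gives 390 nM.

Among the compounds with values here, compound 2 stands as the only true number in this assay; the other value shown is a limit, (the limit of > 20000 nM in this assay, at which 1 of the 2 values shown sits), so no step between measured compounds can be drawn. The unmeasured compound 3 `CC(C)C(=O)Nc1ccc(C(=O)Nc2ccn([C@H]3CC[C@H](O[C@H]4O[C@H](C)[C@@H](N(C)C)[C@H](O)[C@H]4O)[C@@H](C)O3)c(=O)n2)cc1` keeps the sugar-bearing core of compound 2 and changes one group on the carbonyl carbon: 4-((isopropylcarbonyl)amino)phenyl in place of isopentyl on a carbonyl carbon. Compound 1, which reaches only the limit, also carries an aryl amide in place of a plain alkyl chain, but it lacks the sugar of compound 2, so its result says little about what compound 3 will do.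

The account therefore expects a modest loss of potency, estimated as a 3.8-fold higher number from compound 2 to compound 3 (0.59 log units; beyond the scatter). The only anchor for this estimate is compound 2 with its isopentyl amide. Compound 3 is expected to give about 1500 nM in this assay, with a likely range from 300 nM to 10000 nM.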

Compound 3, half-maximal inhibitory concentration: 6630 nM
Beside the measured number, compound 3's estimate is 4.4-fold (0.65 log units) below it; measured number inside the range.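

In this assay, the position on the carbonyl carbon whose other neighbour is an amide-type nitrogen proves sensitive to what it carries: with the sugar-bearing core unchanged, the exchange gives a 17-fold higher number from compound 2 to compound 3 (1.23 log units; beyond the scatter). Within the data shown here, this is the first readable step, and it shows that the position can hold the 4-((isopropylcarbonyl)amino)phenyl group, with its six-membered aromatic ring, only at a clear cost, since compound 3 still gives a true number, 6630 nM. Nothing measured here accounts for the size of this step.

The exchange alters the ring, the added amide and the size of the group all at once, so the compounds shown leave open which of these carries the loss; a plain phenyl or a 4-aminophenyl group on the same carbonyl carbon would begin to separate them. As far as these compounds go, it also remains open how much the alkyl chain itself matters at this position, which a shorter chain such as ethyl or a longer chain such as n-octyl would test against the isopentyl group.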